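Swapping one aryl group on a shared core

The source may report more compounds than this note shows. Statements on the series, on what has been measured and on what is new or still open speak of the compounds shown alone.

- compound 1 `COc1ccc([C@@H]2[C@H](Oc3ccccc3)C(=O)N2c2cc(OC)c(OC)c(OC)c2)cc1OC` gives 26000 nM
- compound 2 `COc1cc(N2C(=O)[C@@H](Oc3ccccc3)[C@H]2c2ccc([N+](=O)[O-])cc2)cc(OC)c1OC` gives 63000 nM
- compound 3 `COc1cc(N2C(=O)[C@@H](Oc3ccccc3)[C@H]2c2ccc(O)cc2)cc(OC)c1OC` gives 48000 nM

In a functional assay on MCF7 cells (Homo sapiens) for antiproliferative activity, read by MTT assay, with stated times of 24 h and 72 h (on this read-out higher numbers stand for weaker inhibition and lower numbers for stronger inhibition), compound 3 gives 48000 nM and cannot be told apart from either of the other two numbers, as a 1.8-fold higher number from compound 1 to compound 3 (0.27 log units; within the scatter) and a 1.3-fold lower number from compound 2 to compound 3 (0.12 log units; within the scatter) show. Compound 4 `COc1ccc([C@@H]2[C@H](Oc3ccccc3)C(=O)N2c2cc(OC)c(OC)c(OC)c2)c(N)c1O` keeps the shared core and changes one group: the 4-hydroxyphenyl on a saturated ring carbon gives way, and the counted difference is a group of 10 heavy atoms (7 carbon, 1 nitrogen, 2 oxygen; one six-membered aromatic ring of carbon only) in place of a group of 7 heavy atoms (6 carbon, 1 oxygen; one six-membered aromatic ring of carbon only), on a saturated ring carbon in this swap.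

All three measured steps concern this same place. Besides the two above, a 2.4-fold higher number from compound 1 to compound 2 (0.38 log units; beyond the scatter) is the only one beyond the scatter, and it is modest. Changes here have so far moved the numbers little. The entering group is nearer in size to the 3,4-dimethoxyphenyl of compound 1 (26000 nM) than to the group it replaces, so a lower number, meaning stronger inhibition, is expected. Going by the values given here, no measured compound carries this group, and a step larger than those seen so far is possible. The estimated change is a 4.8-fold lower number from compound 3 to compound 4 (0.68 log units; beyond the scatter) in this assay for this swap. For compound 4 the expected value is 10000 nM with an estimated range from 300 nM to 60000 nM in all.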

Compound 4, half-maximal inhibitory concentration: 19000 nM
Beside the measured number, compound 4's estimate is 1.9-fold (0.28 log units) below it; low and high end bracket the measured number.
By their numbers in this assay, from the lowest: compounds 4, 1, 3 and 2 (each within the scatter of the next, the first and the last beyond it).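

In this assay, the group of 10 heavy atoms on the saturated ring carbon gives a clear, though modest, gain over two of the earlier groups (a 2.5-fold lower number from compound 3 to compound 4 (0.40 log units; beyond the scatter); a 3.3-fold lower number from compound 2 to compound 4 (0.52 log units; beyond the scatter)). Against the 3,4-dimethoxyphenyl of compound 1, which has the same count of heavy atoms but no nitrogen, the step is too small to separate the two compounds (a 1.4-fold lower number from compound 1 to compound 4 (0.14 log units; within the scatter)), so the new group adds nothing that can be measured beyond what that earlier group already gave. Across the four compounds this position has yet to give a number clearly lower than that of compound 1, and no evidence is at hand to explain any of these steps.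

The compounds shown leave open which part of the entering group matters, since a ring carrying only an amine, or only a methoxy group, would be needed to tell its pieces apart. They also leave open whether a carboxylic acid or a longer chain on this ring could move the number further, and whether replacing the phenoxy group would change the picture at all.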